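The source may hold more compounds than are shown below. What is called first, only, known or untested is meant among the compounds shown, and "the series" means these compounds.

In a functional assay on MCF7 cells (Homo sapiens) (a higher number here means a weaker inhibitor of growth, a lower number a stronger inhibitor of growth), compound 1 (`O=S(=O)(/C=C/c1ccc(F)cc1F)Cc1ccc(Nc2ncnc3ccccc23)cc1`) gives > 100000 nM, which is a limit of the assay and not a number. Compound 2 (`O=S(=O)(/C=C/c1ccc(O)cc1)Cc1ccc(Nc2ncnc3ccc(Br)cc23)cc1`) gives 32000 nM. Compound 3 (`O=S(=O)(/C=C/c1ccc(C(F)(F)F)cc1F)Cc1ccc(Nc2ncnc3ccc(Br)cc23)cc1`) gives 32000 nM, level with compound 2. Compound 4 (`O=S(=O)(/C=C/c1ccc(F)cc1F)Cc1ccc(Nc2ncnc3ccc(Br)cc23)cc1`) differs from compound 3 as follows: fluoro in place of trifluoromethyl on an aromatic carbon. Going by the values given here, the one measured step among groups on this ring shows no change at the digits printed from compound 2 to compound 3 (within the scatter), so no shift beyond the scatter is expected in this assay. The expected step is no change at the digits printed from compound 3 to compound 4 (within the scatter). The estimate for compound 4 is 32000 nM, with an expected range from 12000 nM to 85000 nM.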

Compound 4, concentration for 50% growth inhibition: 100000 nM
Compound 4: middle estimate off by 3.1-fold (0.49 log units), on the low side, and the stated range ends below it.
By their numbers in this assay, from the lowest: compounds 2 and 3 (each within the scatter of the next); then compound 4.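

In this assay the group on this aromatic carbon does count: fluoro in place of trifluoromethyl gives a 3.1-fold higher number from compound 3 to compound 4 (0.49 log units; beyond the scatter) as a modest step. The earlier step on this ring stayed within the scatter, whereas 2,4-difluorophenyl in place of 4-hydroxyphenyl gives a 3.1-fold higher number from compound 2 to compound 4 (0.49 log units; beyond the scatter) as a modest step too. Bromo in place of hydrogen gives a number no higher from compound 1 to compound 4 (the limit leaves the size open) and no more can be said of this step. The value of compound 1 is a limit, so the size of this step cannot be read: the limit of > 100000 nM in this assay, at which 1 of the 4 values shown sits.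

As far as these compounds go, it remains open whether a methoxy group, an amine or a carboxylic acid on this aromatic carbon would read closer to compound 3 or to compound 4.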